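Series notes: aryl change from compound 3 to compound 4

The source may report more compounds than this note shows. Statements on the series, on what has been measured and on what is new or still open speak of the compounds shown alone.

Among the compounds with values here, compound 3 `CCCCCCCCCCCCCCCCCCNC(=O)[C@H]1CSC(c2ccc(C#N)cc2)N1` gives 5900 nM in a functional assay on LNCaP cells (Prostate gland, Homo sapiens) for antiproliferative activity, read by sulforhodamine B assay (a higher number here means a weaker inhibitor, a lower number a stronger inhibitor), the highest of the three numbers measured so far. Compound 1 `CCCCCCCCCCCCCCCCCCNC(=O)[C@H]1CSC(c2cccnc2)N1` gives 3600 nM, and a 1.6-fold higher number from compound 1 to compound 3 (0.21 log units; within the scatter). Compound 2 `CCCCCCCCCCCCCCCCCCNC(=O)[C@H]1CSC(c2cccc(O)c2)N1` gives 1700 nM; a 3.5-fold higher number from compound 2 to compound 3 (0.54 log units; beyond the scatter) and a 2.1-fold lower number from compound 1 to compound 2 (0.33 log units; beyond the scatter). Compound 4 `CCCCCCCCCCCCCCCCCCNC(=O)[C@H]1CSC(c2ccc(F)c(Br)c2)N1` is not yet measured; its change from compound 3 is 3-bromo-4-fluorophenyl in place of 4-cyanophenyl on a saturated ring carbon. All three measured steps vary the aryl group on this same ring carbon, and even the largest of them is modest. None of them brings in a halogenated phenyl, so the direction of this step is open. For compound 4 a small move toward the lower numbers is expected, a 1.5-fold lower number from compound 3 to compound 4 (0.17 log units; within the scatter). Compound 4 is therefore estimated at 4000 nM, with a range from 1500 nM to 9000 nM.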

Compound 4, half-maximal inhibitory concentration: 3000 nM
Compound 4: the middle estimate sits 1.3-fold (0.12 log units) above what was measured; low and high end bracket the measured number.
By their numbers in this assay, from the lowest: compounds 2, 4, 1 and 3 (each within the scatter of the next, the first and the last beyond it).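

Compound 4 places a halogenated phenyl on this saturated ring carbon, and 3-bromo-4-fluorophenyl in place of 4-cyanophenyl gives only a small shift (a 2.0-fold lower number from compound 3 to compound 4 (0.29 log units; within the scatter)). It also does not separate from the other two aryl groups (a 1.8-fold higher number from compound 2 to compound 4 (0.25 log units; within the scatter); a 1.2-fold lower number from compound 1 to compound 4 (0.08 log units; within the scatter)), so its value falls inside the span already set by compound 2 and compound 3. No measured evidence bears on this result.

Still open, going by these compounds, is whether an aminophenyl or a carboxyphenyl at this carbon would move the number further. On these data alone, the effect of a shorter alkyl chain on the amide nitrogen also remains open.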